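From 4-methylphenyl to phenyl in compound 4

The compounds below may be only part of what the source reports. "The series", "measured", "known", "first", "only" and "open" are said of these compounds alone.

Within the data shown here, in a functional assay on MDA-MB-231 cells (Homo sapiens) for antiproliferative activity, read by MTT assay, with a stated time of 96 h (a higher number here means a weaker inhibitor, a lower number a stronger inhibitor), compound 1 `CC(C)=CCC/C(C)=C/CC/C(C)=C/CC[C@]1(C)CCc2cc(OC(=O)NS(=O)(=O)c3ccc(C)cc3)cc(C)c2O1` gives 6600 nM, the only true number among the three compounds measured. Compound 2 `CC(C)=CCC/C(C)=C/CC/C(C)=C/CC[C@]1(C)CCc2c(C)c(OC(=O)Nc3ccccc3)c(C)c(C)c2O1` reads > 10000 nM, which is a limit of the assay and not a number. Compound 3 `CC(C)=CCC/C(C)=C/CC/C(C)=C/CC[C@]1(C)CCc2cc(OC(=O)NS(=O)(=O)c3ccc(C)cc3)c(C)c(C)c2O1` reads > 10000 nM, again a limit.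

Compound 4 `CC(C)=CCC/C(C)=C/CC/C(C)=C/CC[C@]1(C)CCc2cc(OC(=O)NS(=O)(=O)c3ccccc3)cc(C)c2O1` changes compound 1 in one place: 4-methylphenyl becomes phenyl, with hydrogen in place of methyl on an aromatic carbon. Among the measured compounds shown here, no measured step touches this group. The closest comparison swaps the same two substituents on an aromatic carbon of the shared core, in the opposite direction, and shows an at least 1.5-fold higher number from compound 1 to compound 3 (0.18 log units; that floor lies within the scatter). That is only a loose guide, since it lies elsewhere in the molecule and its size is known only as a floor. No shift beyond the scatter is therefore expected in this assay. The estimated step is a 1.0-fold lower number from compound 1 to compound 4 (0.01 log units; within the scatter). Compound 4 is expected at 6500 nM, with an estimated range of 3000 nM to 13000 nM.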

Compound 4, half-maximal inhibitory concentration: > 10000 nM
Compound 4: only a limit was reported (the forecaster's own chance of this, stated with the estimate: 20%); middle value at least 1.5-fold (0.18 log units) from the limit.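

Among these compounds, this is the first reading on the 4-methylphenyl group rather than on the shared core, and in this assay the swap to phenyl gives an at least 1.5-fold higher number from compound 1 to compound 4 (0.18 log units; that floor lies within the scatter). Compound 4 reads > 10000 nM, which is a limit of the assay and not a number. The methyl at this position is therefore not shown to matter beyond the scatter, yet the phenyl compound gives no readable value either, and the true size of the step stays hidden: the limit of > 10000 nM in this assay, at which 3 of the 4 values shown sit.

From the compounds shown here alone, it remains open whether another group in place of this methyl, such as an ethyl, a methoxy or a chlorine, would give a true number. Also open, going by these compounds, is how far compound 4 really lies from compound 1, which only a reading below the limit could tell.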